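A few compounds are considered here, and "the series" means these few. Any claim that something is new, unique, unknown or untested is made for them only; others in the source may bear on it.

Measured in a functional assay on HepG2 cells (Homo sapiens) for antiproliferative activity, read by MTT assay, with a stated time of 72 h; a higher number here means a weaker inhibitor, a lower number a stronger inhibitor:
- Compound 1 `O=C1COc2ccc(-c3cccc(NS(=O)(=O)c4ccc(F)cc4)c3)cc2N1`: > 40000 nM, a limit of the assay
- Compound 2 `COc1cccc(N2C(=O)COc3ccc(-c4cnc5ccccc5c4)cc32)c1`: 2080 nM
- Compound 3 `COc1ncc(-c2ccc3c(c2)N(c2ccccc2)C(=O)CO3)cc1NS(=O)(=O)c1ccc(F)cc1`: 14000 nM

Compound 2, at 2080 nM, has the lower of the two actual numbers, and its gap to compound 3 lies beyond the usual scatter. Compound 4 `O=C1COc2ccc(-c3cnc4ccccc4c3)cc2N1C1CCCCC1` keeps the core of compound 2 but carries cyclohexyl in place of 3-methoxyphenyl on an amide-type nitrogen in a ring. Going by the values given here, no measured pair isolates this change, so the expectation has no direct precedent. In this assay, a moderate move toward a weaker number is expected, and the estimated change is a 2.2-fold higher number from compound 2 to compound 4 (0.34 log units; beyond the scatter). Compound 4 is estimated at 4500 nM, with an expected range of 1500 nM to 20000 nM.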

Compound 4, half-maximal inhibitory concentration: > 40000 nM
Compound 4 gave a limit, no number; the forecaster's own chance of this, stated with the estimate: 10%; at least 8.8-fold (0.94 log units) between middle value and limit.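

In this assay, cyclohexyl in place of 3-methoxyphenyl on the amide-type nitrogen in a ring gives an at least 19-fold higher number from compound 2 to compound 4 (1.28 log units; beyond the scatter), the first step shown at this position. Compound 4 gives > 40000 nM, which is a limit of the assay and not a number, so the step has a floor but no measured size: the limit of > 40000 nM in this assay, at which 2 of the 4 values shown sit. This nitrogen therefore does not tolerate every six-membered carbon ring alike.

On these data alone, whether the loss follows the non-aromatic ring or the missing methoxy oxygen stays open, since this change alters both. A 3-aminophenyl or methoxycyclohexyl group on the core of compound 2 would bear on that.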